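A few compounds are considered here, and "the series" means these few. Any claim that something is new, unique, unknown or untested is made for them only; others in the source may bear on it.

Measured compounds in the series:

- compound 1, `CCOC(=O)c1c(N(C)C)[nH]c2ccc(O)cc12`: "not determined" (no result reported) in an assay on isolated protein for inhibition of Polyunsaturated fatty acid 5-lipoxygenase (Homo sapiens), tested at 10 uM; on this read-out lower numbers stand for less inhibition and higher numbers for more inhibition at the one concentration tested (going by the name of the read-out)
- compound 2, `CCOC(=O)c1c(N2CCN(c3ccccc3)CC2)[nH]c2ccc(O)cc12`: 79%
- compound 3, `CCOC(=O)c1c(Nc2ccc(C)cc2)[nH]c2ccc(O)cc12`: 77%

Compound 3 stands lowest of the two numbers available in this assay, but its nearest neighbour, compound 2, sits only a small way above, and that gap lies within the usual scatter, so the two cannot be ordered. Compound 1 carries no number and gives no footing for comparison.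

The next compound, compound 4, `CCOC(=O)c1c(NC(C)c2ccccc2)[nH]c2ccc(O)cc12`, is not yet measured. It differs from compound 3 in one place: 1-phenylethyl in place of 4-methylphenyl on a nitrogen on an aromatic ring. For the measured compounds named here, no step between measured compounds resembles this change, so nothing itself sets its size. The substituent on that nitrogen stays a single aromatic ring of carbon only, and the nitrogen remains a secondary amine as in compound 3, so the change is expected to cost little; a step of no more than the scatter, or a modest loss, is expected as a number 7 percentage points lower from compound 3 to compound 4 (within the scatter). Compound 4 is therefore estimated at 70% in this assay, with a range from 45% to 88%.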

Compound 4, a percentage reported as inhibition, at one concentration (the size of the read-out at that concentration, not a potency): 72%
Estimate against measurement, compound 4: 2 percentage points below; the measured number falls inside the stated range.
By their numbers in this assay, from the lowest: compounds 4, 3 and 2 (each within the scatter of the next).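

For the compounds shown here, replacing 4-methylphenyl with 1-phenylethyl on a nitrogen on an aromatic ring gives a number 5 percentage points lower from compound 3 to compound 4 (within the scatter) in this assay and provides the first step that can be read at this position. Both groups hold one six-membered aromatic ring of carbon only and leave the nitrogen as a secondary amine, and with these features kept, the read-out does not separate this pair of substituents. Nothing available explains why the two groups read alike.

As far as these compounds go, it remains open whether the read-out holds when this nitrogen carries a group with no aromatic ring, such as a plain butyl chain. Also open, from the compounds shown here alone, is what happens when a carboxylic acid or an amine is placed on the aromatic ring of the 1-phenylethyl group.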